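A few compounds are considered here, and "the series" means these few. Any claim that something is new, unique, unknown or untested is made for them only; others in the source may bear on it.

Three compounds have been measured in a functional assay on SW-620 cells (Homo sapiens) for antiproliferative activity, read by MTT assay, with a stated time of 72 h; a lower number here means a stronger inhibitor, a higher number a weaker inhibitor:

compound 1 `O=C1O/C(=C\Cn2cnc3c(Cl)c(F)nc(F)c32)C(OCc2ccccc2)=C1OCc1ccccc1` gives 50000 nM
compound 2 `O=C1NC(O)(CCn2cnc3cc[nH]c3c2=O)C(OCc2ccccc2)=C1OCc1ccccc1` gives 90700 nM
compound 3 `COc1nc(OC)c2c(ccn2CCC2(O)NC(=O)C(OCc3ccccc3)=C2OCc2ccccc2)n1` gives 90700 nM

Compound 1 has the lowest number of the three, but its distance to compound 2 and to compound 3 is within the usual scatter, so none of the three can be set apart from the others on these numbers. All three are weak in this assay.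

Compound 4 `O=C1O/C(=C\Cn2cnc3cncc(Br)c32)C(OCc2ccccc2)=C1OCc1ccccc1` has not yet been measured. It differs from compound 1 in one place: a group of 10 heavy atoms (6 carbon, 3 nitrogen, 1 bromine; one five-membered aromatic ring with 2 hetero atoms, one six-membered aromatic ring with 1 hetero atom) in place of a group of 12 heavy atoms (6 carbon, 3 nitrogen, 2 fluorine, 1 chlorine; one five-membered aromatic ring with 2 hetero atoms, one six-membered aromatic ring with 1 hetero atom), on a saturated chain carbon bound to a double-bonded chain carbon. The two bicyclic groups share the same ring count and the same count of acceptors, and only the halogens on them differ. Among the measured compounds shown here, no step between measured compounds bears on this exchange, so there is no basis for expecting a shift in either direction beyond the scatter. Compound 4 is therefore expected to come out close to compound 1, with the step of no change at the digits printed from compound 1 to compound 4 (within the scatter) being small. The estimate for compound 4 in this assay is 50000 nM, with a range from 20000 nM to 120000 nM.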

Compound 4, half-maximal inhibitory concentration: 32900 nM
The estimate for compound 4 lay 1.5-fold (0.18 log units) above the measured number; measured number inside the range.
By their numbers in this assay, from the lowest: compounds 4, 1, 2 and 3 (each within the scatter of the next, the first and the last beyond it).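

In this assay, the group of 10 heavy atoms with one bromine in place of the group of 12 heavy atoms with two fluorines and one chlorine gives a 1.5-fold lower number from compound 1 to compound 4 (0.18 log units; within the scatter). Among the compounds shown here, this is the first step read at this place, on a saturated chain carbon bound to a double-bonded chain carbon, and it shows that this exchange of halogens, with the ring count and acceptor count unchanged, leaves the number within the scatter and compound 4, at 32900 nM, still weak. No measurement at hand speaks to what lies behind this step.

The compounds shown leave open whether an amine or a carboxylic acid on the bicyclic group would move the number beyond the scatter. They also leave open what a longer chain at this place would do.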